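This account rests on a few compounds, and the source may have more. Where it says the series, first, only, none or still open, it means among the compounds named here.

Two analogues of the shared core have numbers in a functional assay on Huh-7 cells (Homo sapiens) for inhibition, read by sulforhodamine B assay, with a stated time of 72 h (on this read-out higher numbers stand for weaker inhibition and lower numbers for stronger inhibition), so far. Compound 1 `COc1ccc(C(=O)/C=C/c2cn(-c3ccccc3)nc2-c2ccsc2)cc1OC` gives 2900 nM in this assay. Compound 2 `COc1cc(C(=O)/C=C/c2cn(-c3ccccc3)nc2-c2ccncc2)cc(OC)c1OC` gives 3500 nM in this assay, the higher of the two numbers, though its distance from compound 1 lies within the scatter, so no order between the two can be read. The next compound, compound 3 `COc1ccc(C(=O)/C=C/c2cn(-c3ccccc3)nc2-c2ccncc2)cc1OC`, carries hydrogen in place of methoxy on an aromatic carbon. Among the compounds with values here, no pair of measured compounds isolates this change, so the series gives no direct size for it. The change removes only a methoxy, and the two measured numbers sit close together, so a small step, within the scatter, is expected, with no direction favoured. Because compound 2 gives 3500 nM and compound 1 gives 2900 nM, compound 3 is expected to land near both. The expected step is a 1.2-fold lower number from compound 2 to compound 3 (0.07 log units; within the scatter). The estimate for compound 3 is 3000 nM, with a range from 1200 nM to 7500 nM.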

Compound 3, half-maximal inhibitory concentration: 2000 nM
The estimate for compound 3 lay 1.5-fold (0.18 log units) above the measured number, within the range that was stated.
By their numbers in this assay, from the lowest: compounds 3, 1 and 2 (each within the scatter of the next).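

In this assay the step is a 1.8-fold lower number from compound 2 to compound 3 (0.24 log units; within the scatter) for hydrogen in place of methoxy on an aromatic carbon ortho to a methoxy group and meta to a large group, so this methoxy can be taken away with no effect readable beyond the scatter. Within the data shown here, the step is a 1.5-fold lower number from compound 1 to compound 3 (0.16 log units; within the scatter) for pyridin-4-yl in place of thiophen-3-yl on an aromatic carbon, so this second place, isolated here for the first time, also shows no separation beyond the scatter. No independent data bear on either step.

On these data alone, whether a hydroxyl, an amine or a longer alkoxy chain on the same aromatic carbon would move the number beyond the scatter stays open. The same holds for a phenyl or a carboxylic acid on the aromatic carbon carrying pyridin-4-yl.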